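A pyridyl ether in place of a cyanophenyl

This account rests on a few compounds, and the source may have more. Where it says the series, first, only, none or still open, it means among the compounds named here.

Measured compounds:
compound 1 `CCOc1cccnc1Nc1cccc(C(=O)OC)n1`: 6200 nM
compound 2 `CCOc1cc(-c2ccccc2C#N)cnc1Nc1cccc(C)n1`: 37 nM

Two compounds have numbers in an assay on Ltk cells with metabotropic glutamate receptor 5 (Homo sapiens) as the target, read by fluorescence and calcium flux; on this read-out higher numbers stand for weaker inhibition and lower numbers for stronger inhibition. Compound 1 `CCOc1cccnc1Nc1cccc(C(=O)OC)n1` gives 6200 nM in this assay. Compound 2 `CCOc1cc(-c2ccccc2C#N)cnc1Nc1cccc(C)n1` gives 37 nM in this assay. Compound 2 therefore has the lower of the two numbers, and the gap to compound 1 lies well beyond the scatter. For the measured compounds named here, the two compounds differ in more than one place, so no single change can be read from them, and no step between compounds differing in one place is available.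

Compound 3 `CCOc1cc(Oc2cccnc2)cnc1Nc1cccc(C)n1` has not been measured. It differs from compound 2 in one place: (pyridin-3-yl)oxy in place of 2-cyanophenyl on an aromatic carbon. Going by the values given here, nothing among the measured compounds shows the effect of this kind of exchange, so the expectation rests on the structural change alone. A moderate rise in the number, that is weaker inhibition, is expected, a step of a 5.4-fold higher number from compound 2 to compound 3 (0.73 log units; beyond the scatter) from compound 2 to compound 3, though a result within the scatter cannot be excluded. For compound 3 the estimate is 200 nM, with a range from 40 nM to 1500 nM.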

Compound 3, half-maximal inhibitory concentration: 18 nM
The estimate for compound 3 lay 11-fold (1.05 log units) above the measured number; measured number outside the range, below it.
By their numbers in this assay, from the lowest: compound 3; then compound 2; then compound 1.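

In this assay, the (pyridin-3-yl)oxy group in place of 2-cyanophenyl, on the aromatic carbon two atoms from the ring nitrogen and para to the (6-methylpyridin-2-yl)amino group, gives a 2.1-fold lower number from compound 2 to compound 3 (0.31 log units; beyond the scatter), a modest gain in inhibition. For the compounds shown here, this is the first single-place reading at this position, and it shows that neither the nitrile nor the carbon-only ring of the 2-cyanophenyl group is needed for inhibition at this level, since an oxygen-linked ring with a ring nitrogen serves at least as well. No supporting measurement bears on why the number falls with this exchange.

The compounds shown do not separate the part played by the oxygen link from that of the ring nitrogen, a question that a phenoxy group or a directly attached pyridin-3-yl group on the same carbon would address. From the compounds shown here alone, it also remains open how far this position accepts other kinds of group, such as a morpholine or a carboxylic acid, and whether the ethoxy group could give way to a longer chain.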